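The source may report more compounds than this note shows. Statements on the series, on what has been measured and on what is new or still open speak of the compounds shown alone.

Compound 2 `Cc1c(OCCCCOc2ccccc2C(=O)O)ccc(C(=O)CC2CCCC2)c1O` carries a 2-carboxyphenyl on an oxygen on a saturated carbon. In an assay on HEK293 cells for positive allosteric modulation of metabotropic glutamate receptor 2 (Rattus norvegicus), read by thallium flux, with a stated time of 2.5 min (on this read-out lower numbers stand for smaller maximal responses and higher numbers for larger maximal responses), compound 2 gives 98.8%, the higher of the two numbers measured here. Compound 1 `Cc1c(OCCCCOc2ccc(F)c(C(=O)O)c2)ccc(C(=O)CC2CCCC2)c1O`, with a 3-carboxy-4-fluorophenyl in that place, gives 81% in this assay, and the step between them is a number 17.8 percentage points higher from compound 1 to compound 2 (beyond the scatter). Compound 3 `COc1ccc(C(=O)O)cc1OCCCCOc1ccc(C(=O)CC2CCCC2)c(O)c1C` has not yet been measured. It differs from compound 2 in one place: 5-carboxy-2-methoxyphenyl in place of 2-carboxyphenyl on an oxygen on a saturated carbon. Among the measured compounds shown here, the only measured step that bears on this change is the one between compound 1 and compound 2, which showed that exchanging the 2-carboxyphenyl for a differently substituted carboxyphenyl shifted the largest response beyond the scatter. For the measured compounds named here, compound 3 likewise gives up the 2-carboxyphenyl, and on the strength of a number 17.8 percentage points higher from compound 1 to compound 2 (beyond the scatter) a modest fall is expected, a number 13.8 percentage points lower from compound 2 to compound 3 (beyond the scatter), though the entering group is not the one of compound 1, so its size is uncertain. Compound 3 is therefore estimated to reach 85%, within 68% to 100%.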

Compound 3, largest response reached (reported as percent of maximum), in percent of the reference or control that the assay uses: 91.8%
Compound 3: the middle estimate sits 6.8 percentage points below what was measured; low and high end bracket the measured number.
By their numbers in this assay, from the lowest: compound 1; then compounds 3 and 2 (each within the scatter of the next).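

In this assay, putting the 5-carboxy-2-methoxyphenyl in place of the 2-carboxyphenyl gives a number 7 percentage points lower from compound 2 to compound 3 (within the scatter), so on this oxygen the 2-carboxyphenyl can be given up without a change beyond the usual scatter. The earlier compounds shown here showed only a replacement that cost response; here the two replacing groups differ from each other, with a number 10.8 percentage points higher from compound 1 to compound 3 (beyond the scatter), so the outcome depends on which carboxyphenyl enters. No measurement is available that explains this difference.

On these data alone, all three compounds carry a carboxylic acid on this ring, so what an amide or a tetrazole in its place would give remains open. As far as these compounds go, the 5-carboxy-2-methoxyphenyl also differs from the 2-carboxyphenyl in more than its methoxy group, so the contribution of the methoxy alone remains unknown.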